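The compounds below may be only part of what the source reports. "The series", "measured", "known", "first", "only" and "open" are said of these compounds alone.

Measured so far:
compound 1, `COc1cc(-c2nn(-c3cccc(NC(=O)Nc4ccc(Cl)c(Cl)c4)c3)cc2-c2ccncc2)ccc1Cl`, 2350 nM
compound 2, `COc1cc(-c2nn(-c3cccc(NC(=O)c4ccc(Cl)c(C(F)(F)F)c4)c3)cc2-c2ccncc2)ccc1Cl`, 19700 nM

Both compounds share one core and differ only in the group on the carbonyl carbon. In a functional assay on SK-MEL-2 cells (Homo sapiens) for inhibition, read by sulforhodamine B assay, with a stated time of 48 h (a higher number here means a weaker inhibitor of growth, a lower number a stronger inhibitor of growth), compound 1 gives 2350 nM, and compound 2 gives 19700 nM, the highest of the two numbers; the step of an 8.4-fold higher number from compound 1 to compound 2 (0.92 log units; beyond the scatter) is a modest weakening and goes beyond the scatter.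

Compound 3, `COc1cc(-c2nn(-c3cccc(NC(=O)c4ccccc4)c3)cc2-c2ccncc2)ccc1Cl`, is not yet measured. It differs from compound 2 by phenyl in place of 4-chloro-3-(trifluoromethyl)phenyl on a carbonyl carbon. For the measured compounds named here, no measured step mirrors this change: the one step recorded, from compound 1 to compound 2, exchanges a urea for an amide and tells nothing about the ring substituents themselves. The expectation for compound 3 therefore rests on compound 2 alone, with wide uncertainty, and the step of a 1.5-fold higher number from compound 2 to compound 3 (0.18 log units; within the scatter) is expected to be small, most likely a further weakening. Compound 3 is estimated at 30000 nM in this assay, with a range from 10000 nM to 90000 nM.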

Compound 3, concentration for total growth inhibition: 4970 nM
Estimate against measurement, compound 3: 6.0-fold (0.78 log units) above; measured number outside the range, below it.
By their numbers in this assay, from the lowest: compound 1; then compound 3; then compound 2.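

In this assay, phenyl in place of 4-chloro-3-(trifluoromethyl)phenyl on a carbonyl carbon gives a 4.0-fold lower number from compound 2 to compound 3 (0.60 log units; beyond the scatter) and thus shows that, between these two amides, the unsubstituted ring is the stronger inhibitor of growth. Compound 1 still has the lowest number of the three, but phenyl in place of (3,4-dichlorophenyl)amino gives only a 2.1-fold higher number from compound 1 to compound 3 (0.33 log units; beyond the scatter) and leaves a smaller gap to the urea than compound 2 did. No measurement offered here accounts for this order.

The compounds shown leave open whether the chlorine or the trifluoromethyl matters more in compound 2, as the two occur only together. Also open, going by these compounds, is how the amide would respond to an amine or a carboxylic acid on the phenyl ring, and whether a urea with an unsubstituted phenyl would keep the standing of compound 1.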